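A few compounds are considered here, and "the series" means these few. Any claim that something is new, unique, unknown or untested is made for them only; others in the source may bear on it.

Three compounds share one core and differ only in the group carried on a saturated chain carbon bound to a sulfur. Compound 1 `Oc1c(Br)cc(CSc2nnc(Br)n2Cc2ccc(Br)c3ccccc23)cc1Br` carries a 3,5-dibromo-4-hydroxyphenyl there; in an assay on HEK293 cells for inhibition of solute carrier family 22 member 12 (Homo sapiens) (a lower number here means a stronger inhibitor, a higher number a weaker inhibitor), compound 1 gives 119000 nM. Compound 2 `O=C(CSc1nnc(Br)n1Cc1ccc(Br)c2ccccc12)NO` carries a hydroxycarbamoyl in place of that group, and in this assay compound 2 gives 640 nM, a change of a 190-fold lower number from compound 1 to compound 2 (2.27 log units; beyond the scatter). Compound 3 `O=S(=O)(CSc1nnc(Br)n1Cc1ccc(Br)c2ccccc12)Nc1cccnc1` carries a (pyridin-3-yl)sulfamoyl; in this assay compound 3 gives 32 nM, the lowest of the three numbers, reached through a 3700-fold lower number from compound 1 to compound 3 (3.57 log units; beyond the scatter) and through a 20-fold lower number from compound 2 to compound 3 (1.30 log units; beyond the scatter).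

Compound 4 `O=S(=O)(CSc1nnc(Br)n1Cc1ccc(Br)c2ccccc12)Nc1ccc(F)nc1` keeps the sulfamoyl and alters only the pyridine ring: fluoro in place of hydrogen on an aromatic carbon. None of the three measured steps touches this ring; each of them exchanged the whole group on the chain carbon, and each was large. The single-atom change in compound 4 has no measured counterpart among these compounds, so no step beyond the scatter is expected in either direction. Compound 4 is therefore expected to give about 32 nM in this assay, within a range from 12 nM to 90 nM. The expected step is thus no change at the digits printed from compound 3 to compound 4 (within the scatter), a difference no larger than the scatter.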

Compound 4, half-maximal inhibitory concentration: 1550 nM
Beside the measured number, compound 4's estimate is 48-fold (1.69 log units) below it; measured number above the stated range.
By their numbers in this assay, from the lowest: compound 3; then compound 2; then compound 4; then compound 1.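

Among the compounds shown here, until this result, every large step in this assay came from exchanging the whole group on the chain carbon, so nothing showed how sensitive the pyridine ring itself might be. Here the change is far smaller, one hydrogen giving way to one fluoro on the aromatic carbon next to the ring nitrogen, yet it produces a 48-fold higher number from compound 3 to compound 4 (1.69 log units; beyond the scatter), a step also classed as large, so even a single added heavy atom at this position can weaken inhibition substantially. The compounds shown offer no measurement that explains this loss.

On these data alone, it remains open whether the loss is specific to fluoro or would follow any replacement of that hydrogen, a question that a chloro, a methyl or an amino group at the same place could help to answer. Also open, as far as these compounds go, is whether the other carbons of the pyridine ring are equally sensitive, which could be tested by placing the same fluoro, or a methyl, on each of them in turn.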